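The source may report more compounds than this note shows. Statements on the series, on what has been measured and on what is new or still open speak of the compounds shown alone.

Measured compounds:
Compound 1 `CC(=O)Nc1ccc(-c2nc3cc(C(F)(F)F)ccc3n2C2CCCCC2)cc1`: 30000 nM
Compound 2 `O=[N+]([O-])c1ccc(-c2nc3cc(C(F)(F)F)ccc3n2C2CCCCC2)cc1`: > 100000 nM
Compound 3 `O=[N+]([O-])c1ccc(-c2nc3cc(Cl)c(Cl)cc3[nH]2)cc1`: >= 100000 nM

In an ADME assay on Vero cells (Chlorocebus sabaeus) for cytotoxicity (a higher number here means that more compound is tolerated, a lower number that less compound is tolerated), compound 1 gives 30000 nM. For compound 2 the result is only a limit of the assay, > 100000 nM. Compound 3 also gives only a limit, >= 100000 nM. Compound 2 and compound 1 differ by acetamido in place of nitro on an aromatic carbon, and that change made the step of an at least 3.3-fold lower number from compound 2 to compound 1 (0.52 log units; beyond the scatter). The difference between the core of compound 3 and the core of compound 2 is not broken down here. Compound 4 `CC(=O)Nc1ccc(-c2nc3cc(Cl)c(Cl)cc3[nH]2)cc1` is not yet measured; it differs from compound 3 by acetamido in place of nitro on an aromatic carbon, the same change seen between compound 2 and compound 1. The estimated step is an at least 3.3-fold lower number from compound 3 to compound 4 (0.52 log units; beyond the scatter), set beside an at least 3.3-fold lower number from compound 2 to compound 1 (0.52 log units; beyond the scatter). Compound 4 is therefore expected to give about 30000 nM, between 10000 nM and 100000 nM.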

Compound 4, half-maximal cytotoxic concentration: > 100000 nM
Compound 4 was reported as a limit; the forecaster's own chance of this, stated with the estimate: 25%; at least 3.3-fold (0.52 log units) between middle value and limit.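

In this assay, going by these compounds alone, compound 3 and compound 4 both give only limits of the assay, and no step between them can be read. The compounds shown leave open whether acetamido in place of nitro changes the tolerated concentration on the core of compound 3 at all.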